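The compounds below may be only part of what the source reports. "The series", "measured", "known", "first", "only" and "open" are said of these compounds alone.

Measured compounds in an assay on microsomes for inhibition of Amine oxidase [flavin-containing] B (Homo sapiens), read by fluorescence and spectrophotometry, with a stated time of 20 min; a higher number here means a weaker inhibitor, a lower number a stronger inhibitor:
- compound 1 `Cn1c(=O)c2c(nc(SCCc3ccc(F)cc3)n2C)n(C)c1=O`: 71 nM
- compound 2 `Cn1c(=O)c2c(nc(SCCc3cccc(Br)c3)n2C)n(C)c1=O`: 40 nM
- compound 3 `Cn1c(=O)c2c(nc(SCc3cccc(Cl)c3)n2C)n(C)c1=O`: 227 nM

Compound 3 stands at the highest number of the three. The two steps reaching it, a 3.2-fold higher number from compound 1 to compound 3 (0.50 log units; beyond the scatter) and a 5.7-fold higher number from compound 2 to compound 3 (0.75 log units; beyond the scatter), both go up beyond the scatter, each pairing a shortening of the chain with a change of the ring substituent.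

Compound 4 `Cn1c(=O)c2c(nc(SCc3cccc(Br)c3)n2C)n(C)c1=O` differs from compound 3 by bromo in place of chloro on an aromatic carbon. Among the compounds with values here, no measured step swaps one halogen for another at the same place on the ring, so nothing bears on it directly. The closest comparison is a 1.8-fold lower number from compound 1 to compound 2 (0.25 log units; within the scatter), which changes both the halogen and its place on the ring and still stays within the scatter. That compound 2 carries bromo and gives the lowest number while compound 3 carries chloro and gives the highest is confounded by the chain difference and cannot be read as a halogen effect.

The step of a 1.3-fold lower number from compound 3 to compound 4 (0.10 log units; within the scatter) is therefore expected to stay within the scatter, leaning at most slightly downward. Compound 4 is estimated at 180 nM, with a range from 80 nM to 450 nM.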

Compound 4, half-maximal inhibitory concentration: 199 nM
Compound 4: the middle estimate sits 1.1-fold (0.04 log units) below what was measured; measured number inside the range.
By their numbers in this assay, from the lowest: compounds 2 and 1 (each within the scatter of the next); then compounds 4 and 3 (each within the scatter of the next).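

In this assay the swap at this place on the ring, meta to a large group, gives a 1.1-fold lower number from compound 3 to compound 4 (0.06 log units; within the scatter), so on the shorter chain bromo and chloro cannot be told apart. Within the data shown here, with the 3-bromophenyl group held constant, a 5.0-fold higher number from compound 2 to compound 4 (0.70 log units; beyond the scatter) isolates the chain difference for the first time and shows that the shorter chain alone gives a higher number beyond the scatter, while a 2.8-fold higher number from compound 1 to compound 4 (0.45 log units; beyond the scatter) points the same way but also changes the halogen and its place on the ring. Nothing available explains why either change does or does not shift the number.

Going by these compounds, whether bromo and chloro also match on the longer chain of compound 2 remains open. So does what a still longer chain, or an amine or a carboxylic acid in place of the halogen, would do.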